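This account rests on a few compounds, and the source may have more. Where it says the series, first, only, none or still open, it means among the compounds named here.

Of the compounds shown here, two have so far been measured in a functional assay on Ehrlich cells (Homo sapiens) for cytotoxicity, read by MTT assay, with a stated time of 48 h; a lower number here means a stronger inhibitor, a higher number a weaker inhibitor. Compound 1, `Cc1noc2c1N=C(c1ccco1)CC(c1ccccc1)C2C(c1ccccc1)C1c2onc(C)c2N=C(c2ccco2)CC1c1ccccc1`, gives 28.9 ug/mL. Compound 2, `Cc1ccc(C(C2c3onc(C)c3N=C(c3ccccc3)CC2c2ccccc2)C2c3onc(C)c3N=C(c3ccccc3)CC2c2ccccc2)cc1`, gives 48.2 ug/mL. Compound 2 has the higher of the two numbers, but its gap to compound 1 lies within the scatter, so the two cannot be placed in order. Compound 3, `COc1ccc(C(C2c3onc(C)c3N=C(c3ccccc3)CC2c2ccccc2)C2c3onc(C)c3N=C(c3ccccc3)CC2c2ccccc2)cc1`, has not yet been measured; it differs from compound 2 by methoxy in place of methyl on an aromatic carbon. Among the compounds with values here, no pair of measured compounds differs in one place, and compound 1 and compound 2 differ from each other at several points, so no step of this kind has been seen. For compound 3 the expected change is none beyond the scatter, a step of a 1.1-fold lower number from compound 2 to compound 3 (0.03 log units; within the scatter). Compound 3 is therefore estimated at 45 ug/mL, with a range from 22 ug/mL to 90 ug/mL.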

Compound 3, half-maximal inhibitory concentration: 41.9 ug/mL
Beside the measured number, compound 3's estimate is 1.1-fold (0.03 log units) above it, and the stated range covers the measured number.
By their numbers in this assay, from the lowest: compounds 1, 3 and 2 (each within the scatter of the next).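

Within the data shown here, compound 2 and compound 3 give the first pair that differs in one place, and so the first direct reading of this position, an aromatic carbon para to a large group. The exchange of 4-methylphenyl for 4-methoxyphenyl gives a 1.2-fold lower number from compound 2 to compound 3 (0.06 log units; within the scatter) in this assay, so the two compounds cannot be told apart, and in this pair the methoxy group, with its added oxygen and hydrogen-bond acceptor, brings no detectable difference from methyl. No independent data bear on why the two readings agree.

The compounds shown do not tell how an amine, a carboxylic acid or a chlorine atom on the same carbon would read. A single exchange between methyl and methoxy also cannot show whether this position tolerates other groups in general.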